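One Nitro-to-Bromo Swap, Measured Once and Expected Again

This account rests on a few compounds, and the source may have more. Where it says the series, first, only, none or still open, it means among the compounds named here.

Of the compounds shown here, three have been tested in a functional assay on SF-268 cells (Homo sapiens) for inhibition, read by sulforhodamine B assay, with a stated time of 48 h; on this read-out higher numbers stand for weaker inhibition of growth and lower numbers for stronger inhibition of growth. Compound 1 `N#CCC(=O)N/N=C(/CBr)c1ccc(Br)cc1` gives 12800 nM in this assay, and compound 2 `N#CCC(=O)N/N=C(/CBr)c1ccc([N+](=O)[O-])cc1` gives 14000 nM. Among the measured compounds shown here, the one change between them is bromo in place of nitro on an aromatic carbon, and it made a 1.1-fold lower number from compound 2 to compound 1 (0.04 log units; within the scatter). Compound 3 `N#CCC1=NN=C(c2ccc([N+](=O)[O-])cc2)C(CC(=O)c2ccc([N+](=O)[O-])cc2)O1` gives 2000 nM in this assay; the difference between its core and the core of compound 2 is not broken down here.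

Compound 4 `N#CCC1=NN=C(c2ccc([N+](=O)[O-])cc2)C(CC(=O)c2ccc(Br)cc2)O1` is not yet measured. It differs from compound 3 by bromo in place of nitro on an aromatic carbon, the same change that separates compound 2 from compound 1. Because that change made a 1.1-fold lower number from compound 2 to compound 1 (0.04 log units; within the scatter), the expected step here is a 1.1-fold higher number from compound 3 to compound 4 (0.02 log units; within the scatter). Compound 4 is therefore estimated at 2100 nM in this assay, within a range from 700 nM to 6000 nM.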

Compound 4, concentration for 50% growth inhibition: 16500 nM
Estimate against measurement, compound 4: 7.9-fold (0.90 log units) below; measured number outside the range, above it.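

In this assay, the swap from nitro to bromo gave an 8.3-fold higher number from compound 3 to compound 4 (0.92 log units; beyond the scatter), so the change did not carry across with the same size, and the two cores responded differently: the same change on two cores in this assay, a 1.1-fold lower number (0.04 log units; within the scatter) from compound 2 to compound 1 and an 8.3-fold higher number (0.92 log units; beyond the scatter) from compound 3 to compound 4, 9.0-fold (0.96 log units) apart, beyond the scatter of two such steps

A step read on one of these cores is therefore a poor guide to the same change on the other. Among the compounds shown here, with only two pairs, this does not show why the cores differ, or which response is more usual across the series.

The compounds shown carry only nitro or bromo at this position on the ring. As far as these compounds go, whether an amine or a carboxylic acid there would keep the growth inhibition seen with compound 3 remains open.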